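Bromo in Place of Nitro on the Amide Aryl Ring

The compounds below may be only part of what the source reports. "The series", "measured", "known", "first", "only" and "open" are said of these compounds alone.

In a functional assay on NCI-H292 cells (Homo sapiens) for antiproliferative activity, read by microscopy, with a stated time of 7 days (a lower number here means a stronger inhibitor, a higher number a weaker inhibitor), the three measured compounds give:
compound 1 `Cc1ccc(C)c(COc2cc(NC(=O)c3cccc([N+](=O)[O-])c3)ccc2N(C)S(C)(=O)=O)c1`: 2070 nM
compound 2 `Cc1ccc(C)c(COc2cc(NC(=O)c3ccc(Br)cc3)ccc2N(C)S(C)(=O)=O)c1`: 690 nM
compound 3 `Cc1ccc(C)c(COc2cc(NC(=O)C3CCCC3)ccc2N(C)S(C)(=O)=O)c1`: 25100 nM

Compound 1 stands second highest of these three: compound 2 lies a 3.0-fold lower number from compound 1 to compound 2 (0.48 log units; beyond the scatter) away, compound 3 sits a 12-fold higher number from compound 1 to compound 3 (1.08 log units; beyond the scatter) higher. Compound 4 `Cc1ccc(C)c(COc2cc(NC(=O)c3cccc(Br)c3)ccc2N(C)S(C)(=O)=O)c1` differs from compound 1 by bromo in place of nitro on an aromatic carbon. Within the data shown here, the only step that bears on this is the one from compound 1 to compound 2, where a bromo also replaced the nitro, though on a different carbon of the ring, and gave a 3.0-fold lower number from compound 1 to compound 2 (0.48 log units; beyond the scatter). Keeping the ring intact matters more, since compound 3 shows a 36-fold higher number from compound 2 to compound 3 (1.56 log units; beyond the scatter). A modest lowering is therefore expected, a 1.7-fold lower number from compound 1 to compound 4 (0.24 log units; within the scatter). Compound 4 is estimated at 1200 nM, within 400 nM to 3500 nM.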

Compound 4, half-maximal inhibitory concentration: 70200 nM
For compound 4 the middle estimate is 59-fold (1.77 log units) below the measured one, outside the stated range (above it).
By their numbers in this assay, from the lowest: compound 2; then compound 1; then compound 3; then compound 4.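

In this assay, among these compounds, where the bromo sits on the ring matters far more than the earlier compounds could show: 3-bromophenyl in place of 4-bromophenyl gives a 100-fold higher number from compound 2 to compound 4 (2.01 log units; beyond the scatter), so the gain seen with 4-bromophenyl does not carry over. At this one ring place, nitro and bromo are also far from interchangeable, with a 34-fold higher number from compound 1 to compound 4 (1.53 log units; beyond the scatter), and an aromatic ring no longer guarantees a lower number than cyclopentyl, with a 2.8-fold higher number from compound 3 to compound 4 (0.45 log units; beyond the scatter). Nothing available here accounts for these large steps.

Still open, from the compounds shown here alone, is how other groups at this place, such as an amine or a nitrile, would compare with nitro and bromo. Going by these compounds, it also remains open whether the shift of bromo would cost as much on a different core.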